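The source may report more compounds than this note shows. Statements on the series, on what has been measured and on what is new or still open speak of the compounds shown alone.

Measured in a functional assay on NCI-H460 cells (Homo sapiens) for cytotoxicity, read by MTT assay, with a stated time of 48 h; a higher number here means a weaker inhibitor, a lower number a stronger inhibitor:
- compound 1 `C=C1C(=O)O[C@H]2CC3=C[C@H](C/C(C)=C/[C@@H](OC(=O)CCCCC)[C@H]12)OC3=O`: 5900 nM
- compound 2 `C=C1C(=O)O[C@H]2CC3=C[C@H](C/C(C)=C/[C@@H](OC(=O)CC4CCCCC4)[C@H]12)OC3=O`: 2000 nM
- compound 3 `C=C1C(=O)O[C@H]2CC3=C[C@H](C/C(C)=C/[C@@H](OC(=O)C4(NC(=O)OCc5ccccc5)CC4)[C@H]12)OC3=O`: 3000 nM

Compound 2 and compound 3 lie within the scatter of each other, so these two cannot be ranked. Compound 1 stands apart from compound 2, with the higher number. The unmeasured compound 4 `C=C1C(=O)O[C@H]2CC3=C[C@H](C/C(C)=C/[C@@H](OC(=O)c4ccncc4)[C@H]12)OC3=O` keeps the shared core of compound 2 and changes only the group on the ester. The difference is pyridin-4-yl in place of cyclohexylmethyl on a carbonyl carbon, which means pyridin-4-yl in place of cyclohexylmethyl on a carbonyl carbon.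

Going by the values given here, only one measured step bears directly on this group, and it is modest: a 3.0-fold lower number from compound 1 to compound 2 (0.47 log units; beyond the scatter). It swaps one saturated group for another, so it is a loose guide at best. Among the compounds with values here, no measured compound has an aromatic ring on that carbonyl carbon, and the data therefore do not show what such a ring does. Compound 3, at 3000 nM, carries a very different group in this region, yet its number stays close to that of compound 2. A large change in this assay therefore seems unlikely, with a slight lean towards a higher number. The expected change is a 1.5-fold higher number from compound 2 to compound 4 (0.18 log units; within the scatter), which is no step beyond the scatter. For compound 4 the estimated value is 3000 nM, with an expected range from 1200 nM to 8000 nM.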

Compound 4, half-maximal inhibitory concentration: 5600 nM
For compound 4 the middle estimate is 1.9-fold (0.27 log units) below the measured one; the range from low to high includes it.
By their numbers in this assay, from the lowest: compounds 2, 3, 4 and 1 (each within the scatter of the next, the first and the last beyond it).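

In this assay, the first aromatic ring on this carbonyl carbon gives a 2.8-fold higher number from compound 2 to compound 4 (0.45 log units; beyond the scatter), so replacing cyclohexylmethyl with pyridin-4-yl makes a readable difference, which the earlier saturated groups could not reveal. Against the simple chain of compound 1, the same ring gives a 1.1-fold lower number from compound 1 to compound 4 (0.02 log units; within the scatter), so compound 1 and compound 4 cannot be ranked, and pyridin-4-yl does no better here than pentyl, while cyclohexylmethyl stands apart from both. No measurement available here explains this difference.

As far as these compounds go, the step from compound 2 to compound 4 alters several things at once: the ring becomes aromatic, it gains a nitrogen, and the methylene link of cyclohexylmethyl is lost, so the part that matters remains unknown. A phenyl group on the same carbonyl carbon would help to separate the effect of the nitrogen from that of the aromatic ring, and a cyclohexyl group there would show what the link contributes.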